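The compounds below may be only part of what the source reports. "The series", "measured", "known", "first", "only" and "open" are said of these compounds alone.

In a functional assay on HCT-116 cells (Homo sapiens) for antiproliferative activity, read by MTT assay, with a stated time of 48 h (a higher number here means a weaker inhibitor, a lower number a stronger inhibitor), compound 3 (`COc1cc(N(Cc2ccccc2)C(=O)CSc2nc3ccccc3s2)cc(OC)c1OC`) gives 54500 nM. It sits at the high end of the three numbers, together with compound 2 (`COc1cc(CN(C(=O)CSc2nc3ccccc3s2)c2cc(OC)c(OC)c(OC)c2)cc(OC)c1OC`), which gives 65300 nM. The gap between them is a 1.2-fold lower number from compound 2 to compound 3 (0.08 log units; within the scatter). Compound 1 (`COc1ccc(CN(C(=O)CSc2nc3ccccc3s2)c2cc(OC)c(OC)c(OC)c2)cc1`) stands well apart at 426 nM.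

The next compound, compound 4 (`COc1ccc(CN(C(=O)CSc2nc3ccccc3s2)c2cc(OC)c(OC)c(OC)c2)cc1F`), changes compound 3 at one place: 3-fluoro-4-methoxyphenyl in place of phenyl on a saturated chain carbon bound to an amide-type nitrogen. In short, 3-fluoro-4-methoxyphenyl stands in place of phenyl on a saturated chain carbon bound to an amide-type nitrogen.

The closest measured precedent is compound 1, which carries 4-methoxyphenyl at that place and shows a 130-fold higher number from compound 1 to compound 3 (2.11 log units; beyond the scatter) on losing its methoxy. Compound 2 is the warning, since 3,4,5-trimethoxyphenyl there gives a 150-fold higher number from compound 1 to compound 2 (2.19 log units; beyond the scatter). Going by the values given here, no measured compound carries fluoro, so the range stays wide.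

A large step to a lower number is expected, estimated as a 61-fold lower number from compound 3 to compound 4 (1.78 log units; beyond the scatter). The estimated value for compound 4 is 900 nM, with an expected range from 200 nM to 8000 nM.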

Compound 4, half-maximal inhibitory concentration: 1830 nM
Compound 4: middle estimate off by 2.0-fold (0.31 log units), on the low side; the measured number falls inside the stated range.
By their numbers in this assay, from the lowest: compound 1; then compound 4; then compounds 3 and 2 (each within the scatter of the next).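

In this assay, going by these compounds alone, the benzyl to 3-fluoro-4-methoxybenzyl change gives a large gain over the unsubstituted group (a 30-fold lower number from compound 3 to compound 4 (1.47 log units; beyond the scatter)) and over the 3,4,5-trimethoxyphenyl group (a 36-fold lower number from compound 2 to compound 4 (1.55 log units; beyond the scatter)), so the 4-methoxyphenyl of compound 1 is no longer the only group here that stands clear of compounds 2 and 3. Extra substitution on 4-methoxyphenyl is therefore not always as costly as in compound 2, although fluoro still gives a modest loss (a 4.3-fold higher number from compound 1 to compound 4 (0.63 log units; beyond the scatter)). No supporting measurement is available to explain these differences.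

On these data alone, it remains open whether 3-fluorophenyl without the methoxy would keep this activity. Also open, as far as these compounds go, is how chloro in place of fluoro, or hydroxy or an amine in place of the methoxy, would compare with compound 1.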